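A Benzyl Swap on a Weak Inhibitor

The source may report more compounds than this note shows. Statements on the series, on what has been measured and on what is new or still open speak of the compounds shown alone.

Two compounds set the scene in a functional assay on MGC-803 cells (Homo sapiens) for inhibition, read by CCK-8 assay, with a stated time of 48 h; on this read-out lower numbers stand for stronger inhibition and higher numbers for weaker inhibition. Compound 1 (`COc1ccc(CN(C(=O)CSC(=S)N2CCN(C(=O)OC(C)(C)C)CC2)c2ccc(C)cc2)cc1`) reads > 20000 nM, which is a limit of the assay and not a number. Among the measured compounds shown here, compound 2 (`COc1cc(N(Cc2ccc(C)cc2)C(=O)CSC(=S)N2CCN(C(=O)OC(C)(C)C)CC2)cc(OC)c1OC`) gives 16700 nM, the only true number available so far and a weak result on this read-out. Compound 3 (`COc1ccc(CN(C(=O)CSC(=S)N2CCN(C(=O)OC(C)(C)C)CC2)c2cc(OC)c(OC)c(OC)c2)cc1N`) differs from compound 2 in one group: 3-amino-4-methoxyphenyl in place of 4-methylphenyl on a saturated chain carbon bound to an amide-type nitrogen. In words, 3-amino-4-methoxyphenyl stands in place of 4-methylphenyl on a saturated chain carbon bound to an amide-type nitrogen. For the measured compounds named here, no measured pair shows what such a change does, so any forecast is tentative. With compound 2 at 16700 nM, there is wide room toward stronger inhibition, and a clear gain beyond the scatter is expected. The expected move is a 19-fold lower number from compound 2 to compound 3 (1.27 log units; beyond the scatter). Compound 3 is estimated at 900 nM, within a range of 60 nM to 10000 nM.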

Compound 3, half-maximal inhibitory concentration: 184 nM
The estimate for compound 3 lay 4.9-fold (0.69 log units) above the measured number; measured number inside the range.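

Among the compounds shown here, the change from 4-methylbenzyl to 3-amino-4-methoxybenzyl in this assay gives a 91-fold lower number from compound 2 to compound 3 (1.96 log units; beyond the scatter), the first measured step at this position. It shows that the group on the saturated chain carbon bound to an amide-type nitrogen can strongly change the read-out, even with the rest of compound 2 left as it is. Compound 1 adds no second step, because its reading is a limit and not a number: the limit of > 20000 nM in this assay, at which 1 of the 3 values shown sits.

The swap removes a methyl group and brings in an amino and a methoxy group in a single move, so this pair cannot tell which of these changes accounts for the gain. Phenyl rings carrying only the amino group, as in 3-aminophenyl, or a hydroxy group in its place, as in 3-hydroxy-4-methoxyphenyl, would help to separate those contributions.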